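A few compounds are considered here, and "the series" means these few. Any claim that something is new, unique, unknown or untested is made for them only; others in the source may bear on it.

Measured so far:
Compound 1 `O=c1ccn(COCCOP(=O)(O)O)c(=O)[nH]1` gives > 500000 nM in a functional assay on NG108-15 cells for antagonist activity at P2Y purinoceptor 2 (Mus musculus), read by fluorescence and calcium flux, with a stated time of 30 min; a lower number here means a stronger inhibitor, a higher number a weaker inhibitor; this is a limit of the assay, not a number.
Compound 2 `O=c1ccn(COCCCOP(=O)(O)O)c(=O)[nH]1` gives 338000 nM in this assay.
Compound 3 `O=c1ccn(CCCCOP(=O)(O)O)c(=O)[nH]1` gives <= 500000 nM in this assay; this is a limit of the assay, (the limit of <= 500000 nM in this assay, at which 1 of the 3 values shown sits).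

Compound 3 therefore stands at a cap on the number rather than at a number. The reading of compound 2 and the limit of compound 3 cannot be set in order against each other, and compound 1 sits at the other limit, (the limit of > 500000 nM in this assay, at which 1 of the 3 values shown sits).

Compound 4 `O=c1ccn(CCCCCOP(=O)(O)O)c(=O)[nH]1` differs from compound 3 in one place: a group of 6 heavy atoms (1 carbon, 4 oxygen, 1 phosphorus; no ring) in place of a group of 5 heavy atoms (4 oxygen, 1 phosphorus; no ring), on a saturated chain carbon, four bonds along the chain from an aromatic nitrogen. Among the measured compounds shown here, the only measured step of the same kind is an at least 1.4-fold lower number from compound 1 to compound 2 (0.17 log units; that floor lies within the scatter), and its floor lies within the scatter, so it gives no firm direction. For compound 4 in this assay no step beyond the scatter is expected, and the step that the limit leaves unreadable from compound 3 to compound 4 is the expected outcome. The estimate for compound 4 is 300000 nM, with a range from 100000 nM to 600000 nM, and a fair chance that the assay again returns only a limit.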

Compound 4, half-maximal inhibitory concentration: 267000 nM
For compound 4 the middle estimate is 1.1-fold (0.05 log units) above the measured one, and the stated range covers the measured number.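

The step from compound 3 to compound 4 cannot be read, as compound 3 stands only at a limit of the assay: the limit of <= 500000 nM in this assay, at which 1 of the 4 values shown sits.

The compounds shown leave open whether a group of 6 heavy atoms in place of a group of 5 heavy atoms, on a saturated chain carbon, moves the number in this assay beyond the scatter.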